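A Third Methoxy Group and the Tolerated Concentration

The source may report more compounds than this note shows. Statements on the series, on what has been measured and on what is new or still open speak of the compounds shown alone.

In an ADME assay on MDBK cells (Bos taurus) for cytotoxicity, read by MTT assay, with a stated time of 96 h (a higher number here means that more compound is tolerated, a lower number that less compound is tolerated), compound 1 `COc1ccc(-c2nc3cc(C(C)O)ccc3[nH]2)cc1` gives > 100000 nM, a limit of the assay.
In this assay compound 2 `COc1ccc(-c2nc3cc(C(C)O)ccc3[nH]2)c(OC)c1` gives > 100000 nM, also a limit of the assay.
In this assay compound 3 `COc1ccc(-c2nc3cc(/C(C)=N/O)ccc3[nH]2)c(OC)c1` gives > 100000 nM, again a limit of the assay.

From compound 1 to compound 2 the change is methoxy in place of hydrogen on an aromatic carbon, and the step is a step that the two limits leave unreadable from compound 1 to compound 2. From compound 2 to compound 3 the step is a step that the two limits leave unreadable from compound 2 to compound 3. What both steps share is the limit of > 100000 nM in this assay, at which 3 of the 3 values shown sit, so no size can be read from either of them.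

Compound 4 `COc1ccc(-c2nc3cc(/C(C)=N/O)ccc3[nH]2)c(OC)c1OC` has not yet been measured. It differs from compound 3 by methoxy in place of hydrogen on an aromatic carbon, the same kind of change as from compound 1 to compound 2, though here the place is ortho to two methoxy groups and meta to a large group, whereas the earlier place was ortho to a large group and meta to a methoxy group. The difference between the core of compound 1 and the core of compound 3 is not broken down here.

The step from compound 3 to compound 4 in this assay is expected to be a number no higher from compound 3 to compound 4 (the limit leaves the size open), which rests on the earlier change of the same kind leaving compound 2 at the limit of > 100000 nM in this assay, at which 3 of the 3 values shown sit. Compound 4 is estimated at 100000 nM, with a range from 50000 nM to 200000 nM.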

Compound 4, half-maximal cytotoxic concentration: > 100000 nM
Compound 4 gave a limit, no number; the forecaster's own chance of this, stated with the estimate: 85%; the middle value sits exactly at the limit.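

In this assay compound 4 gives > 100000 nM, a limit of the assay and not a number. The step from compound 3 to compound 4 therefore cannot be read, as with the earlier steps: the limit of > 100000 nM in this assay, at which 4 of the 4 values shown sit.

The compounds shown leave open whether the methoxy groups or the difference between the cores change the tolerated concentration at all.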